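Same aryl swap, now on a sulfonyl sulfur

The compounds below may be only part of what the source reports. "The series", "measured", "known", "first", "only" and "open" are said of these compounds alone.

Of the compounds shown here, three sharing one amide-bearing core have been tested in a functional assay on CWR22R cells (Homo sapiens) for antiproliferative activity, read by propidium iodide staining, with a stated time of 96 h; a lower number here means a stronger inhibitor, a higher number a weaker inhibitor. Compound 1 `CC(O)(CSc1ccc(F)cc1)C(=O)Nc1cccc(S(F)(F)(F)(F)F)c1` gives 30200 nM in this assay. Compound 2 `CC(O)(CSc1cccc(C(F)(F)F)c1)C(=O)Nc1cccc(S(F)(F)(F)(F)F)c1` differs from compound 1 by 3-(trifluoromethyl)phenyl in place of 4-fluorophenyl on a sulfur. In this assay compound 2 gives 12900 nM, so that the change made a 2.3-fold lower number from compound 1 to compound 2 (0.37 log units; beyond the scatter). Compound 3 `CC(O)(CS(=O)(=O)c1ccc(F)cc1)C(=O)Nc1cccc(S(F)(F)(F)(F)F)c1` carries its aryl group on a sulfonyl sulfur rather than on a plain sulfur; how its core differs from that of compound 1 is not broken down here. In this assay compound 3 gives 38900 nM, a number that lies within the usual scatter of that of compound 1, while compound 2 sits clearly lower.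

Compound 4 `CC(O)(CS(=O)(=O)c1cccc(C(F)(F)F)c1)C(=O)Nc1cccc(S(F)(F)(F)(F)F)c1` has not been measured. It differs from compound 3 by 3-(trifluoromethyl)phenyl in place of 4-fluorophenyl on a sulfonyl sulfur. Among the compounds with values here, this is the same kind of change as the one from compound 1 to compound 2, but not the same: there the place was described as a sulfur whose other neighbour is a saturated chain carbon, here as a sulfonyl sulfur whose other neighbour is a saturated chain carbon.

Within the data shown here, with only that earlier step to lean on, the expectation for the move from compound 3 to compound 4 is a step of about a 2.2-fold lower number from compound 3 to compound 4 (0.33 log units; beyond the scatter), resting on the fact that compound 1 to compound 2 gave a 2.3-fold lower number from compound 1 to compound 2 (0.37 log units; beyond the scatter). On that basis compound 4 is estimated to give about 18000 nM in this assay, with a plausible range from 8000 nM to 40000 nM.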

Compound 4, half-maximal inhibitory concentration: 24600 nM
The estimate for compound 4 lay 1.4-fold (0.14 log units) below the measured number; measured number inside the range.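

Replacing 4-fluorophenyl with 3-(trifluoromethyl)phenyl on a sulfonyl sulfur gives, in this assay, a 1.6-fold lower number from compound 3 to compound 4 (0.20 log units; within the scatter), so taken alone this step cannot be told apart from the ordinary variation between repeated measurements. The more useful test is to set it beside the same swap on a plain sulfur, and the two steps do not measurably disagree: the same change on two cores in this assay, a 2.3-fold lower number (0.37 log units; beyond the scatter) from compound 1 to compound 2 and a 1.6-fold lower number (0.20 log units; within the scatter) from compound 3 to compound 4, 1.5-fold (0.17 log units) apart, within the scatter of two such steps This fits the idea that the change carries over from the core of compound 1 to the core of compound 3 with a similar effect, but it does not prove that the effect is identical, it offers no explanation for the effect, and one pair of steps cannot establish a rule for other cores in the series.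

The compounds shown leave open whether the same swap would behave alike on a sulfinyl sulfur, which would carry one oxygen rather than the two of the sulfonyl group. They also leave open what would happen if a nitrile, a chlorine or an amine took the place of trifluoromethyl on the aromatic ring attached to that sulfur.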